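Chloro in place of methyl on the shared core

A few compounds are considered here, and "the series" means these few. Any claim that something is new, unique, unknown or untested is made for them only; others in the source may bear on it.

The study concerns a series built on the shared core of compound 1 `CCN(CC)Cc1cc(F)cc(Nc2nc3ccccc3n2Cc2ccc(C(F)(F)F)cc2)c1O`, compound 2 `CC(C)(C)NCc1cc(Cl)cc(Nc2nc3ccccc3n2Cc2ccc(C(F)(F)F)cc2)c1O`, compound 3 `CCN(CC)Cc1cc(C)cc(Nc2nc3ccccc3n2Cc2ccc(C(F)(F)F)cc2)c1O` and the not yet measured compound 4 `CCN(CC)Cc1cc(Cl)cc(Nc2nc3ccccc3n2Cc2ccc(C(F)(F)F)cc2)c1O`. In an ADME assay on CHO cells (Cricetulus griseus) for inhibition, read by MTT assay (a lower number here means a stronger inhibitor, a higher number a weaker inhibitor), compound 1 reaches only the limit of the assay and gives no number, > 50000 nM. In this assay compound 2 gives 36300 nM, and compound 3 gives 29300 nM. Of the two numbers shown, compound 3 gives the lower one, but its gap to compound 2 lies within the usual scatter, so no order between them can be read from these data.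

One measured step runs to compound 3: an at least 1.7-fold lower number from compound 1 to compound 3 (0.23 log units; that floor lies within the scatter), a step whose floor is set by the limit of > 50000 nM in this assay, at which 1 of the 3 values shown sits, and which therefore lies within the scatter.

Compound 4 differs from compound 3 by chloro in place of methyl on an aromatic carbon. For the measured compounds named here, no measured step covers this exact exchange. The closest guide is compound 2, which also carries chloro at this position and, with a different aminomethyl group, gives a number within the scatter of compound 3. The account therefore expects no change beyond the scatter, a 1.2-fold higher number from compound 3 to compound 4 (0.08 log units; within the scatter). Compound 4 is estimated at 35000 nM, with a range from 15000 nM to 80000 nM.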

Compound 4, half-maximal inhibitory concentration: > 50000 nM
Compound 4: only a limit was reported (the forecaster's own chance of this, stated with the estimate: 20%); middle value at least 1.4-fold (0.15 log units) away from the limit.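

In this assay, chloro in place of methyl on the aromatic carbon para to a hydroxy group gives an at least 1.7-fold higher number from compound 3 to compound 4 (0.23 log units; that floor lies within the scatter), so this position now has a measured exchange between these two groups, but the step is not shown to exceed the scatter. With chloro held at this position, diethylamino in place of (tert-butyl)amino gives an at least 1.3-fold higher number from compound 2 to compound 4 (0.13 log units; that floor lies within the scatter), so this exchange of the amine is likewise not shown to exceed the scatter. Compound 4 reports a limit and not a number, and the step between compound 1 and compound 4 cannot be read, which leaves the fluoro and chloro compounds unordered: the limit of > 50000 nM in this assay, at which 2 of the 4 values shown sit.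

What the compounds shown leave open is the actual size of the chloro step, and whether hydrogen, bromo or methoxy at this position would give a number in this assay. Also open, on these data alone, is how a piperidine or a morpholine in place of the diethylamino group would read with chloro kept at this position.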